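The source may hold more compounds than are shown below. What is called first, only, known or untested is meant among the compounds shown, and "the series" means these compounds.

Compound 1, `CCN(CC)S(=O)(=O)c1ccc(S(=O)(=O)N2CCC[C@@H](C(=O)N3CCC(O)CC3)C2)cc1`: 4710 nM. Compound 2, `CC(C)CS(=O)(=O)c1ccc(S(=O)(=O)N2CCC[C@@H](C(=O)N3CCC(F)(F)CC3)C2)cc1`: 311 nM.

Of the compounds shown here, two have been measured in a functional assay on BXPC-3 cells (Homo sapiens) for inhibition, read by MTT assay, with a stated time of 7 days; on this read-out higher numbers stand for weaker inhibition and lower numbers for stronger inhibition. Compound 1 gives 4710 nM, the higher of the two numbers, while compound 2 gives 311 nM; the gap between them lies beyond the scatter, but the two structures differ in more than one place, so no single step can be read from them. Compound 3, `CCN(CC)S(=O)(=O)c1ccc(S(=O)(=O)N2CCC[C@@H](C(=O)N[C@H]3CC[C@@H](OC)CC3)C2)cc1`, has not yet been measured. It differs from compound 1 in one place: (4-methoxycyclohexyl)amino in place of 4-hydroxypiperidin-1-yl on a carbonyl carbon. Going by the values given here, no measured pair shows this change, so there is no step to lean on. In this assay the change is therefore expected to bring only a small shift, probably not beyond the scatter, with a slight lean toward a lower number. The expected step, a 1.6-fold lower number from compound 1 to compound 3 (0.20 log units; within the scatter), reflects that caution. Compound 3 is estimated at 3000 nM, with a range from 800 nM to 12000 nM.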

Compound 3, half-maximal inhibitory concentration: 2150 nM
Estimate against measurement, compound 3: 1.4-fold (0.14 log units) above, and the stated range covers the measured number.
By their numbers in this assay, from the lowest: compound 2; then compound 3; then compound 1.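

In this assay, (4-methoxycyclohexyl)amino in place of 4-hydroxypiperidin-1-yl on a carbonyl carbon gives a 2.2-fold lower number from compound 1 to compound 3 (0.34 log units; beyond the scatter), the first single-place step available at this position; it is modest but beyond the scatter. The position therefore accepts a six-membered ring of carbon only in place of one with a hetero atom, with the counts of hydrogen-bond donors and acceptors unchanged, and the number falls rather than rises. Nothing available explains this step.

Since the ring, the methoxy group and the amide nitrogen all change together, the compounds shown cannot separate their contributions, and it remains open how an amine or a carboxylic acid in place of the methoxy group would read. Compound 2 differs from both compound 1 and compound 3 in more than one place, so its steps to them cannot be read.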